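Chain shortening in a small anticonvulsant series

The source may report more compounds than this note shows. Statements on the series, on what has been measured and on what is new or still open speak of the compounds shown alone.

Three compounds have been run so far: compound 1 `CC(C(=O)N1CCN(c2ccccc2F)CC1)N1C(=O)CCC1=O`, compound 2 `CCC(C(=O)N1CCN(c2ccccc2F)CC1)N1C(=O)CCC1=O` and compound 3 `CCC(C(=O)N1CCN(c2cccc(C(F)(F)F)c2)CC1)N1C(=O)CCC1=O`. Compound 4 `CC(C(=O)N1CCN(c2cccc(C(F)(F)F)c2)CC1)N1C(=O)CCC1=O` remains to be tested.

In a functional assay on the whole organism (strain Swiss) with Mus musculus as the target, in the maximal electroshock model, with a stated time of 2 h, at a dose of 300 mg/kg by the intraperitoneal route (on this read-out lower numbers stand for a weaker effect and higher numbers for a stronger effect at the one dose given), compound 1 gives 25%. In this assay compound 2 gives 0%, and in this assay compound 3 gives 50%. Of the three numbers, compound 3 stands highest, beyond the scatter against both others.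

One single-point change is available: hydrogen in place of methyl on a saturated chain carbon, two bonds along the chain from an amide-type nitrogen in a ring and a carbonyl carbon, which produced a number 25 percentage points higher from compound 2 to compound 1 (beyond the scatter). The difference between the core of compound 2 and the core of compound 3 is not broken down here; their values alone show compound 3 well above compound 2.

The change from compound 3 to compound 4 is hydrogen in place of methyl on a saturated chain carbon, two bonds along the chain from an amide-type nitrogen in a ring and a carbonyl carbon, the same change as before, at the same place. Going by the values given here, on that basis, and because the one earlier step was a number 25 percentage points higher from compound 2 to compound 1 (beyond the scatter), an increase of similar size is expected, giving a number 15 percentage points higher from compound 3 to compound 4 (beyond the scatter). The expectation rests on a single precedent, on a different core, so the band is kept wide; the earlier step could also fail to carry over, leaving compound 4 near compound 3. For compound 4 the estimate in this assay is 65%, expected to lie between 30% and 100%.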

Compound 4, a percentage reported as activity, at one dose (the size of the read-out at that dose, not a potency): 100%
For compound 4 the middle estimate is 35 percentage points below the measured one, within the range that was stated.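

In this assay, the ethyl to methyl change gives a number 50 percentage points higher from compound 3 to compound 4 (beyond the scatter), so the direction of the earlier step also holds on the core of compound 3. The direction carries over between these two cores, but the size of the step does not stay the same: the same change on two cores in this assay, a number 25 percentage points higher (beyond the scatter) from compound 2 to compound 1 and a number 50 percentage points higher (beyond the scatter) from compound 3 to compound 4, 25 percentage points apart, beyond the scatter of two such steps The two steps show nothing about why their sizes differ, and two cores are too few to show that the same change would raise the number on any further core; with a single dose, they also say nothing about potency.

Still open, on these data alone, is how the read-out follows the chain beyond the ethyl and methyl pair on either core, for example with a propyl or isopropyl group in place of ethyl, or with hydrogen in place of methyl. Also open, as far as these compounds go, is whether the step keeps its direction when a chloro or methoxy group stands in place of trifluoromethyl on the core of compound 3.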